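The source may report more compounds than this note shows. Statements on the series, on what has been measured and on what is new or still open speak of the compounds shown alone.

In a functional assay on A549 cells (Homo sapiens) for antiproliferative activity, read by MTT assay, with a stated time of 72 h (a higher number here means a weaker inhibitor, a lower number a stronger inhibitor), compound 1 (`O=C1COc2ccc(-c3cccc(NS(=O)(=O)c4ccc(F)cc4)c3)cc2N1`) gives 32100 nM and compound 2 (`COc1ncc(-c2ccc3c(c2)NC(=O)CO3)cc1NS(=O)(=O)c1ccc(F)cc1`) gives 8070 nM as the lower of the two numbers, a gap beyond the scatter. Compound 3 (`COc1ncc(-c2ccc3c(c2)N(c2ccc(F)cc2)C(=O)CO3)cc1NS(=O)(=O)c1ccc(F)cc1`) carries 4-fluorophenyl in place of hydrogen on an amide-type nitrogen in a ring. Among the compounds with values here, no measured step involves this nitrogen, so the expectation remains loose. The estimated 4.5-fold lower number from compound 2 to compound 3 (0.65 log units; beyond the scatter) in this assay is expected to point towards a stronger inhibitor, beyond the scatter. Compound 3 is expected at 1800 nM with an estimated range from 250 nM to 10000 nM around that middle.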

Compound 3, half-maximal inhibitory concentration: 6500 nM
Compound 3: middle estimate off by 3.6-fold (0.56 log units), on the low side, within the range that was stated.
By their numbers in this assay, from the lowest: compounds 3 and 2 (each within the scatter of the next); then compound 1.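

In this assay, 4-fluorophenyl in place of hydrogen on the amide-type nitrogen gives a 1.2-fold lower number from compound 2 to compound 3 (0.09 log units; within the scatter). The amide hydrogen is therefore not needed to hold the level of compound 2, and this nitrogen can carry an aromatic ring with no change beyond the scatter. Nothing measured here speaks to why the number holds. As far as these compounds go, whether a methyl group, a longer chain or a carboxylic acid on this nitrogen would move the number remains open, and a single substituent cannot show a trend at this position.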